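This account rests on a few compounds, and the source may have more. Where it says the series, first, only, none or still open, it means among the compounds named here.

Notes on the series. Going by the values given here, compound 1 `O=C(/C=C/c1ccccc1)NS(=O)(=O)c1ccc(F)cc1` and compound 2 `Cc1ccc(S(=O)(=O)NC(=O)/C=C/c2ccc(Br)cc2)cc1` are the two measured members, both tested in a functional assay on B16-F10 cells (Mus musculus) for antiproliferative activity, read by ELISA and MTT assay, with a stated time of 48 h; a lower number here means a stronger inhibitor, a higher number a weaker inhibitor. Compound 1 gives 2.1 ug/mL. Compound 2 gives 12.1 ug/mL, which is the higher of the two numbers; the gap to compound 1 is beyond the scatter. The two compounds differ in more than one place, so nothing is said here about which part of that difference carries the gap.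

Compound 3 `O=C(/C=C/c1ccc(Br)cc1)NS(=O)(=O)c1ccc(F)cc1` is not yet measured. It differs from compound 2 in one place: fluoro in place of methyl on an aromatic carbon. The same change, taken one bond further out, reads 4-methylphenyl to 4-fluorophenyl, on the ring that carries the sulfonyl group. Compound 1 carries the same fluorophenyl sulfonyl piece and gives 2.1 ug/mL, the lower of the two numbers, so the step from compound 2 to compound 3 is expected to go toward a lower number, by a 2.4-fold lower number from compound 2 to compound 3 (0.38 log units; beyond the scatter). Compound 3 is estimated at 5 ug/mL, with a range from 1.5 ug/mL to 15 ug/mL.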

Compound 3, half-maximal inhibitory concentration: 1.2 ug/mL
For compound 3 the middle estimate is 4.2-fold (0.62 log units) above the measured one; measured number below the stated range.
By their numbers in this assay, from the lowest: compounds 3 and 1 (each within the scatter of the next); then compound 2.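

In this assay, going by these compounds alone, the change from 4-methylphenyl to 4-fluorophenyl on the ring carrying the sulfonyl group, with the bromo kept, reads a 10-fold lower number from compound 2 to compound 3 (1.00 log units; beyond the scatter), giving a first single-place step at this position, beyond the scatter. Bromo in place of hydrogen on an aromatic carbon, with the fluoro kept, reads a 1.8-fold lower number from compound 1 to compound 3 (0.24 log units; within the scatter), within the scatter, so this change shows no separable effect on the number in this pair. No measurement bears on what lies behind either step.

Whether the methyl-to-fluoro step has the same size without the bromo remains open, as the methyl compound lacking bromo is not among those shown. Also open, on these data alone, is how chloro, methoxy or an amine at the same ring position would compare with fluoro and methyl.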